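A few compounds are considered here, and "the series" means these few. Any claim that something is new, unique, unknown or untested is made for them only; others in the source may bear on it.

Of the compounds shown here, three sharing one core have been measured in an assay on isolated protein (strain Sprague-Dawley) for inhibition of Amine oxidase [flavin-containing] A (Rattus norvegicus), read by spectrophotometry, with a stated time of 5 min, tested at 10 uM; a lower number here means less inhibition, a higher number more inhibition at the concentration tested (going by the name of the read-out). Compound 1 `CC(=O)COc1cc(=O)oc2cc(OCc3cccc(Cl)c3)ccc12` gives 22%. Compound 2 `CCOC(=O)COc1cc(=O)oc2cc(OCc3cccc(Cl)c3)ccc12` gives 0%, and compound 3 `CNC(=O)COc1cc(=O)oc2cc(OCc3cccc(Cl)c3)ccc12` gives 11%. Among these three numbers compound 3 stands second highest: compound 1 lies nearest, higher by a margin beyond the scatter, and compound 2 lies furthest, lower by a margin beyond the scatter. The two steps that reach compound 3 are a number 11 percentage points lower from compound 1 to compound 3 (beyond the scatter) and a number 11 percentage points higher from compound 2 to compound 3 (beyond the scatter), both modest; the remaining step, a number 22 percentage points lower from compound 1 to compound 2 (beyond the scatter), is modest as well.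

Compound 4 `O=C(COc1cc(=O)oc2cc(OCc3cccc(Cl)c3)ccc12)N1CCCCC1` has not yet been measured in this assay. It differs from compound 3 in one place: piperidin-1-yl in place of methylamino on a carbonyl carbon. Among the compounds with values here, none of the measured steps exchanges one amine on the carbonyl carbon for another, so none bears directly on this change; together they show only that alterations at this carbonyl carbon have shifted the read-out by modest amounts, downward in one case and upward in the other. The step of a number 1 percentage points higher from compound 3 to compound 4 (within the scatter) is therefore expected to remain within the scatter. The estimate for compound 4 is 12%, with a range from 0% to 30%.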

Compound 4, a percentage reported as inhibition, at one concentration (the size of the read-out at that concentration, not a potency): 9%
Compound 4: middle estimate off by 3 percentage points, on the high side, and the stated range covers the measured number.
By their numbers in this assay, from the lowest: compounds 2, 4 and 3 (each within the scatter of the next, the first and the last beyond it); then compound 1.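

In this assay, the step to a ring on this carbonyl carbon is a number 2 percentage points lower from compound 3 to compound 4 (within the scatter): methylamino, with 2 heavy atoms and 1 hydrogen-bond donor, gives way to piperidin-1-yl, with 6 heavy atoms, a six-membered non-aromatic ring and 0 hydrogen-bond donors, and the read-out does not separate the two. Compound 4 also does not separate from the ethoxy compound, with a number 9 percentage points higher from compound 2 to compound 4 (within the scatter), although compound 3 did, while the comparison with the methyl compound gives a number 13 percentage points lower from compound 1 to compound 4 (beyond the scatter), so compound 1 keeps the highest number of the four and both amides lie beyond the scatter from it. No measurement is available that would explain these results.

Going by these compounds, it remains open whether a carboxylic acid, an unsubstituted amide, a morpholin-4-yl amide or a ketone with a longer chain in this place would reach or pass the number of compound 1. Since each compound is read at a single concentration, the compounds shown also leave open how their potencies compare.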